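Compound 1 and the Step to Compound 4

A few compounds are considered here, and "the series" means these few. Any claim that something is new, unique, unknown or untested is made for them only; others in the source may bear on it.

Among the compounds with values here, in a functional assay on SW-620 cells (Homo sapiens) for inhibition, read by MTT assay, with a stated time of 72 h (a higher number here means a weaker inhibitor, a lower number a stronger inhibitor), compound 1 `COc1cc(NC(C)CCCNC(=O)Nc2ccc(F)cc2)c2ncccc2c1` gives 25000 nM, the highest of the three numbers measured so far. Compound 2 `COc1cc(NC(C)CCCNC(=O)Nc2cc(C(F)(F)F)cc(C(F)(F)F)c2)c2ncccc2c1` gives 3900 nM, and compound 3 `COc1cc(NC(C)CCCNC(=O)NNC(=O)Nc2cccc(F)c2)c2ncccc2c1` gives 9500 nM. Compound 4 `COc1cc(NC(C)CCCNC(=O)NNC(=O)Nc2cccc(Cl)c2)c2ncccc2c1` has not yet been measured. Its difference from compound 1 is ((3-chlorophenyl)carbamoyl)amino in place of 4-fluorophenyl on an amide-type nitrogen: ((3-chlorophenyl)carbamoyl)amino stands in place of 4-fluorophenyl on an amide-type nitrogen.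

Within the data shown here, one measured step bears directly on this change. Putting ((3-fluorophenyl)carbamoyl)amino in that same place gave a 2.6-fold lower number from compound 1 to compound 3 (0.42 log units; beyond the scatter), a modest gain beyond the scatter. Among the measured compounds shown here, the new group in compound 4 differs from that one only in carrying 3-chlorophenyl rather than 3-fluorophenyl, and no measured pair shows what that exchange alone does. A step of similar size and in the same direction is therefore expected. In this assay the expected step is a 3.1-fold lower number from compound 1 to compound 4 (0.49 log units; beyond the scatter). For compound 4 the estimated value is 8000 nM, with an expected range of 3000 nM to 20000 nM.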

Compound 4, half-maximal inhibitory concentration: 25000 nM
Estimate against measurement, compound 4: 3.1-fold (0.49 log units) below; the whole stated range lies below it.
By their numbers in this assay, from the lowest: compound 2; then compound 3; then compounds 1 and 4 (each within the scatter of the next).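

In this assay, the extended group on the amide-type nitrogen brings no gain of its own: ((3-chlorophenyl)carbamoyl)amino in place of 4-fluorophenyl gives no lower number, with no change at the digits printed from compound 1 to compound 4 (within the scatter) for this change. The earlier gain at this position therefore did not carry over to every group of this kind, since chloro in place of fluoro on an aromatic carbon gives a 2.6-fold higher number from compound 3 to compound 4 (0.42 log units; beyond the scatter) and leaves compound 4 without the advantage held by compound 3. Nothing measured here explains why this single exchange matters.

The compounds shown leave open whether a bromo, methyl or methoxy group on that ring would follow compound 3 or compound 4. They also leave open how the same extended group would behave with two trifluoromethyl groups on the ring, as in compound 2.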